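The compounds below may be only part of what the source reports. "The series", "measured", "known", "first", "only" and "open" are said of these compounds alone.

Measured so far:
Compound 1, `O=C(O)C1=Cc2ccccc2OC1(OCc1cc(-c2ccc(F)cc2)no1)C(F)(F)F`, in a functional assay on HeLa cells (Homo sapiens) for inhibition, read by MTT assay, with a stated time of 24 h (on this read-out higher numbers stand for weaker inhibition and lower numbers for stronger inhibition), gives > 150000 nM, a limit of the assay rather than a number.
Compound 2, `CCOC(=O)C1=Cc2ccccc2OC1(OCc1cn(-c2ccc(C)cc2)nn1)C(F)(F)F`, in this assay gives 25100 nM.

Among the compounds with values here, compound 2 therefore stands as the only real number in this assay; the other result is only a limit, as the limit of > 150000 nM in this assay, at which 1 of the 2 values shown sits, shows. Within the data shown here, compound 1 and compound 2 differ in more than one place, so no single step between them can be read.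

Compound 3, `CCOC(=O)C1=Cc2ccccc2OC1(OCc1cn(-c2ccc(F)c([N+](=O)[O-])c2)nn1)C(F)(F)F`, is compound 2 with one change: 4-fluoro-3-nitrophenyl in place of 4-methylphenyl on an aromatic nitrogen. Among the measured compounds shown here, no step between measured compounds is available to lean on, so in this assay the change from compound 2 to compound 3 is expected to stay within the usual scatter, giving an estimated step of a 1.3-fold lower number from compound 2 to compound 3 (0.10 log units; within the scatter). Compound 3 is expected to come out near 20000 nM, with a likely range from 6000 nM to 70000 nM.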

Compound 3, half-maximal inhibitory concentration: 15600 nM
Compound 3: the middle estimate sits 1.3-fold (0.11 log units) above what was measured; low and high end bracket the measured number.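

Within the data shown here, this is the first step that can be read at this place, on an aromatic nitrogen of the five-membered ring with 3 nitrogen. In this assay, putting 4-fluoro-3-nitrophenyl in place of 4-methylphenyl gives a 1.6-fold lower number from compound 2 to compound 3 (0.21 log units; within the scatter), so even this exchange of a methyl group for a fluorine and a nitro group on the aromatic ring does not move the number beyond the scatter. Nothing measured here bears on why the step is this size.

As far as these compounds go, whether an amine or a carboxylic acid on this aromatic ring, or a longer chain in its place, would move the number beyond the scatter stays open. Steps involving compound 1, whose result is only a limit and whose structure differs in more than one place, cannot be read.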